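Thiazole in Place of Methoxyphenyl on the Three-Membered Ring

This account rests on a few compounds, and the source may have more. Where it says the series, first, only, none or still open, it means among the compounds named here.

All four compounds share one core, and differ only in the amine chain and in the aromatic group bound to a three-membered non-aromatic ring of carbon only. Compound 1 `CC(C)CCNCCN(C(=O)[C@@H]1C[C@H]1c1ccccc1)c1ccc(-c2ccccc2)cc1` gives 5.1 nM in a functional assay for agonist activity at G protein-coupled receptor 88 (Homo sapiens), read by HTRF and cAMP accumulation; a lower number here means that less compound is needed, a higher number that more compound is needed for the effect. Within the data shown here, compound 2 `O=C([C@@H]1C[C@H]1c1ccccc1)N(CCNCC1CCCC1)c1ccc(-c2ccccc2)cc1` gives 2.5 nM in this assay, and the single change between them, a 2.0-fold lower number from compound 1 to compound 2 (0.31 log units; beyond the scatter), is the only measured step in this set. Compound 3 `CC[C@H](C)[C@H](N)CN(C(=O)[C@@H]1C[C@H]1c1ccc(OC)cc1)c1ccc(-c2ccccc2)cc1` differs from both in its amine chain and in the aromatic group on the three-membered ring. In this assay compound 3 gives only a limit, > 25000 nM, and so it sits at the limit of > 25000 nM in this assay, at which 1 of the 3 values shown sits. Compound 4 `CC[C@H](C)[C@H](N)CN(C(=O)[C@@H]1C[C@H]1c1nccs1)c1ccc(-c2ccccc2)cc1` is reached from compound 3 by 1,3-thiazol-2-yl in place of 4-methoxyphenyl on a saturated ring carbon. Among the measured compounds shown here, no measured step involves this change; the one known step, between compound 1 and compound 2, concerns a different part of the molecule and offers no guide here. The only anchor is the limit of compound 3, so compound 4 is expected to remain at or near that limit, with the step of a number no higher from compound 3 to compound 4 (the limit leaves the size open) estimated as no real change. Compound 4 is estimated at 25000 nM, within a range from 5000 nM to 25000 nM.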

Compound 4, half-maximal effective concentration: 210 nM
Compound 4: middle estimate off by 120-fold (2.08 log units), on the high side, outside the stated range (below it).
By their numbers in this assay, from the lowest: compound 2; then compound 1; then compound 4. At a limit, above all of these: compound 3.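

In this assay, putting 1,3-thiazol-2-yl in place of 4-methoxyphenyl on a saturated ring carbon of the three-membered ring gives an at least 110-fold lower number from compound 3 to compound 4 (2.07 log units; beyond the scatter), which shows that the aromatic group at this place can, with the amine chain unchanged, move a compound from the limit of the assay to a readable number. Among these compounds, the only earlier step, a 2.0-fold lower number from compound 1 to compound 2 (0.31 log units; beyond the scatter), lay in the amine chain and said nothing about this position, and the change here is large where that one was modest. The true size of the new step stays open at one end, since it starts from a value that is only a limit: the limit of > 25000 nM in this assay, at which 1 of the 4 values shown sits.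

The compounds shown leave open whether the gain comes from adding the five-membered ring or from losing the methoxy group, a question that a plain phenyl on this same amine chain would address. They also leave open how a close relative such as 1,3-oxazol-2-yl or pyridin-2-yl would behave here, and whether 1,3-thiazol-2-yl keeps its effect on the amine chains of compound 1 and compound 2.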